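A Phenyl Ring Enters a Second Time

The source may report more compounds than this note shows. Statements on the series, on what has been measured and on what is new or still open speak of the compounds shown alone.

Three compounds have been measured in an ADME assay on WI-38 cells (Homo sapiens) for inhibition, read by CellTiter-Glo, with a stated time of 48 h, tested at 100 uM; a lower number here means less inhibition, a higher number more inhibition at the concentration tested (going by the name of the read-out):

compound 1, `CC(C)(CO)[C@H](O)C(=O)N/C=C/C(=O)OCc1ccccc1`: 19%
compound 2, `COC(=O)/C=C/NC(=O)[C@@H](O)C(C)(C)CO`: -18%
compound 3, `COC(=O)/C=C\NC(=O)[C@@H](O)C(C)(C)CO`: -20%

Compounds 2 and 3 share all atoms and bonds; their cores differ by the two compounds have the same atoms and bonds and differ only in configuration as drawn: 1 of 2 stereo elements differ; a double bond is drawn E in compound 2 and Z in compound 3, and in this assay the step is a number 2 percentage points lower from compound 2 to compound 3 (within the scatter). From compound 2 to compound 1 the change is phenyl in place of hydrogen on a saturated chain carbon bound to an oxygen next to a carbonyl group, and it produced a number 37 percentage points higher from compound 2 to compound 1 (beyond the scatter).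

Compound 4, `CC(C)(CO)[C@H](O)C(=O)N/C=C\C(=O)OCc1ccccc1`, is not yet measured. It stands to compound 3 as compound 1 stands to compound 2: phenyl in place of hydrogen on a saturated chain carbon bound to an oxygen next to a carbonyl group. The place of the change is described in the same words in both pairs, so this is the same change. Because a number 37 percentage points higher from compound 2 to compound 1 (beyond the scatter) was large while a number 2 percentage points lower from compound 2 to compound 3 (within the scatter) lay within the scatter, compound 4 is expected to show a step of a number 37 percentage points higher from compound 3 to compound 4 (beyond the scatter). Compound 4 is thus estimated at 17%, between 0% and 35%.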

Compound 4, a percentage reported as inhibition, at one concentration (the size of the read-out at that concentration, not a potency): -2%
The estimate for compound 4 lay 19 percentage points above the measured number; the whole stated range lies above it.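

In this assay the phenyl change again gives a higher number on the second core, but the step reads a number 18 percentage points higher from compound 3 to compound 4 (beyond the scatter) against the earlier a number 37 percentage points higher from compound 2 to compound 1 (beyond the scatter) and so its size did not carry over: the same change on two cores in this assay, a number 37 percentage points higher (beyond the scatter) from compound 2 to compound 1 and a number 18 percentage points higher (beyond the scatter) from compound 3 to compound 4, 19 percentage points apart, beyond the scatter of two such steps. The double bond drawn Z instead of E tells the same story from the other side, with a number 2 percentage points lower from compound 2 to compound 3 (within the scatter) for the pair without the phenyl but a number 21 percentage points lower from compound 1 to compound 4 (beyond the scatter) for the pair with it. The direction of the change thus held on both cores while its size did not; the data do not show why, and two pairs give no rule for the wider series.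

The compounds shown leave open whether an amine or a longer chain in place of the benzyl would behave alike on the two cores.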